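Removing Both Chlorines from the Terminal Ring

The source may hold more compounds than are shown below. What is called first, only, known or untested is meant among the compounds shown, and "the series" means these compounds.

Compound 1 `O=C(O)c1cc(-c2ccc(-c3ccc(Cl)cc3Cl)cc2)n(-c2ccc(Cl)cc2Cl)n1` is the starting point. In an assay on isolated protein for inhibition of methionine--tRNA ligase, cytoplasmic (Homo sapiens) (on this read-out lower numbers stand for stronger inhibition and higher numbers for weaker inhibition), compound 1 gives 11900 nM, the lowest of the two numbers shown. Compound 2 `O=C(O)c1cc(-c2ccc(-c3ccc(Cl)cc3Cl)cc2)n(-c2cccnc2)n1` gives 47000 nM in this assay. Compound 3 `O=C(O)c1cc(-c2ccc(-c3ccc(Cl)cc3Cl)cc2)n(Cc2cccnc2)n1` reached only the limit of this assay, > 100000 nM, so no number is known for it (the limit of > 100000 nM in this assay, at which 1 of the 3 values shown sits). The measured steps were a 3.9-fold higher number from compound 1 to compound 2 (0.60 log units; beyond the scatter), an at least 8.4-fold higher number from compound 1 to compound 3 (0.92 log units; beyond the scatter) and an at least 2.1-fold higher number from compound 2 to compound 3 (0.32 log units; beyond the scatter); all three concern the group on the aromatic nitrogen of the shared core, and each weakened inhibition.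

Compound 4 `O=C(O)c1cc(-c2ccc(-c3ccccc3)cc2)n(-c2ccc(Cl)cc2Cl)n1` differs from compound 1 at a different place: phenyl in place of 2,4-dichlorophenyl on an aromatic carbon. Going by the values given here, no measured step changes this terminal ring, so the earlier steps bear on it only indirectly, by showing that every departure from compound 1 so far cost potency. A modest weakening is therefore expected, roughly a 2.1-fold higher number from compound 1 to compound 4 (0.32 log units; beyond the scatter). Compound 4 is estimated to give 25000 nM in this assay, plausibly between 8000 nM and 80000 nM.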

Compound 4, half-maximal inhibitory concentration: 44300 nM
Compound 4: the middle estimate sits 1.8-fold (0.25 log units) below what was measured; the range from low to high includes it.
By their numbers in this assay, from the lowest: compound 1; then compounds 4 and 2 (each within the scatter of the next). At a limit, above all of these: compound 3.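

Until now every change sat on the aromatic nitrogen of the shared core; this one leaves that group alone and shows that the terminal ring also matters. In this assay, replacing 2,4-dichlorophenyl with plain phenyl brings a 3.7-fold higher number from compound 1 to compound 4 (0.57 log units; beyond the scatter) and so shows that inhibition at this position depends on the two chlorines, not on the ring alone. Nothing measured here explains why losing the chlorines weakens inhibition.

The compounds shown leave open whether both chlorines are needed or a single one would be enough. They also leave open whether a fluorine, a methyl group or a methoxy group could stand in for the chlorines on this ring and restore the inhibition seen with compound 1.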